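Cytotoxicity notes on compounds 1 to 3

This account rests on a few compounds, and the source may have more. Where it says the series, first, only, none or still open, it means among the compounds named here.

compound 1 `N#Cc1c(-c2ccccc2)c(C#N)c(=O)n(/N=C/c2cn(-c3ccccc3)nc2-c2ccccc2)c1N`: 180 ug/mL
compound 2 `N#Cc1c(-c2ccc(F)cc2)c(C#N)c(=O)n(/N=C/c2cn(-c3ccccc3)nc2-c2ccccc2)c1N`: > 200 ug/mL

In an ADME assay on NIH3T3 cells (Mus musculus) for cytotoxicity, read by MTT assay (on this read-out lower numbers stand for stronger inhibition and higher numbers for weaker inhibition), compound 1 gives 180 ug/mL. For compound 2 the read-out is a limit of the assay, > 200 ug/mL, so compound 2 stands at the ceiling of the numbers shown (the limit of > 200 ug/mL in this assay, at which 1 of the 2 values shown sits). Among the compounds with values here, the only measured step, an at least 1.1-fold higher number from compound 1 to compound 2 (0.04 log units; that floor lies within the scatter), lies within the scatter. Compound 3 `N#Cc1c(-c2cccc([N+](=O)[O-])c2)c(C#N)c(=O)n(/N=C/c2cn(-c3ccccc3)nc2-c2ccccc2)c1N` differs from compound 2 by 3-nitrophenyl in place of 4-fluorophenyl on an aromatic carbon. Within the data shown here, no measured step touches a nitro group, and the one measured change stayed within the scatter, so no step beyond the scatter is expected in this assay. Compound 3 is estimated at 200 ug/mL (range 110 ug/mL to 350 ug/mL), an expected step of a number no higher from compound 2 to compound 3 (the limit leaves the size open).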

Compound 3, half-maximal inhibitory concentration: 124 ug/mL
The estimate for compound 3 lay 1.6-fold (0.21 log units) above the measured number, and the stated range covers the measured number.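

Nitro in place of hydrogen on the aromatic ring at this position, opposite the ring nitrogen, gives a 1.5-fold lower number from compound 1 to compound 3 (0.16 log units; within the scatter) in this assay, so this first group with hydrogen-bond acceptors here leaves the read-out within the scatter of the parent. Against the 4-fluorophenyl group, the comparison gives only a floor, an at least 1.6-fold lower number from compound 2 to compound 3 (0.20 log units; that floor lies within the scatter). Compound 2 reads as a limit of the assay: the limit of > 200 ug/mL in this assay, at which 1 of the 3 values shown sits.

On these data alone, whether any group at this position can move the read-out beyond the scatter remains open. An amine or a carboxylic acid on this aromatic ring would test that.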